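Swapping the furan ring for a dienyl chain

The source may report more compounds than this note shows. Statements on the series, on what has been measured and on what is new or still open speak of the compounds shown alone.

Measured compounds, in a functional assay on MCF7 cells (Homo sapiens) for cytotoxicity, read by MTT assay, with a stated time of 48 h; on this read-out lower numbers stand for stronger inhibition and higher numbers for weaker inhibition:
Compound 1 `CCCCCCCCCCCCNC(=O)[C@@H](NC(=O)c1ccco1)[C@@H](C)O` gives 67500 nM.
Compound 2 `CCCCCCCCCCCCCCNC(=O)[C@@H](NC(=O)c1ccco1)[C@@H](C)O` gives 105000 nM.

The two compounds share one core and differ only in the length of the saturated chain on the amide-type nitrogen; that step, a 1.6-fold higher number from compound 1 to compound 2 (0.19 log units; within the scatter), leaves them within the usual scatter of each other, so neither can be called the stronger in this assay.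

Compound 3 `C/C=C/C=C/C(=O)N[C@H](C(=O)NCCCCCCCCCCCCCC)[C@@H](C)O` is not yet measured. It keeps the chain of compound 2 and alters the other end: penta-1,3-dien-1-yl in place of furan-2-yl on a carbonyl carbon. Among the compounds with values here, no measured step touches this part of the molecule, so the only known step gives no guidance on it. With nothing to build on, compound 3 is expected to stay near compound 2, the step of a 1.1-fold lower number from compound 2 to compound 3 (0.02 log units; within the scatter) being estimated as no change beyond the scatter but with a wide range. The estimate for compound 3 in this assay is 100000 nM, expected to fall between 30000 nM and 330000 nM.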

Compound 3, half-maximal inhibitory concentration: 27800 nM
Estimate against measurement, compound 3: 3.6-fold (0.56 log units) above; the measured number lies below the stated range.
By their numbers in this assay, from the lowest: compound 3; then compounds 1 and 2 (each within the scatter of the next).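

In this assay, the group on the carbonyl carbon moves the number further than the change in chain length did: penta-1,3-dien-1-yl in place of furan-2-yl gives a 3.8-fold lower number from compound 2 to compound 3 (0.58 log units; beyond the scatter), a modest step but one beyond the scatter, whereas the chain step stayed within it. This end of the molecule can therefore shift the cytotoxicity read-out, and with the chain of compound 2 a five-membered aromatic ring is not required at this place for the lower number. No measurement is available that accounts for this difference.

The swap removes a ring and its oxygen and brings in two double bonds all at once, so the compounds shown cannot tell which of these changes matters. On these data alone, a saturated pentyl chain or a phenyl ring on the same carbonyl carbon would help separate them, and whether the dienyl gain carries over to the shorter chain of compound 1 remains open.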